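Swapping a Sulfo Chain for a Dimethylamino Chain

A few compounds are considered here, and "the series" means these few. Any claim that something is new, unique, unknown or untested is made for them only; others in the source may bear on it.

Compound 3 `N=c1sc2cc(OC(F)(F)F)ccc2n1CCS(=O)(=O)O` was tested in a functional assay on the whole organism with Rattus norvegicus as the target (on this read-out higher numbers stand for an effect only at larger amounts of compound and lower numbers for an effect already at smaller amounts), and gave > 10 mg/kg, which is a limit of the assay rather than a number. Going by the values given here, compound 3 is the one compound that sits at the limit of > 10 mg/kg in this assay, at which 1 of the 3 values shown sits. For comparison, compound 1 `CCCc1ccc2nc(N)sc2c1` gives 6 mg/kg in this assay, and compound 2 `CC(C)(C)c1ccc2nc(N)sc2c1` gives 4 mg/kg, a step of a 1.5-fold lower number from compound 1 to compound 2 (0.18 log units; within the scatter). Compound 4 `CN(C)CCn1c(=N)sc2cc(OC(F)(F)F)ccc21` differs from compound 3 by dimethylamino in place of sulfo on a saturated chain carbon, two bonds along the chain from an aromatic nitrogen. Among the compounds with values here, the only measured step concerns a group on an aromatic carbon and does not bear on this change, so the expectation rests on the measured compounds alone, with wide uncertainty. The step from compound 3 to compound 4 is expected to be an at least 1.6-fold lower number from compound 3 to compound 4 (0.22 log units; that floor lies within the scatter). Compound 4 is estimated at 6 mg/kg in this assay, between 2 mg/kg and 20 mg/kg.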

Compound 4, dose for half-maximal effect: 2.3 mg/kg
Estimate against measurement, compound 4: 2.6-fold (0.42 log units) above; low and high end bracket the measured number.
By their numbers in this assay, from the lowest: compounds 4, 2 and 1 (each within the scatter of the next, the first and the last beyond it). At a limit, above all of these: compound 3.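

At this position, two bonds along the chain from an aromatic nitrogen, the group at the end of the chain clearly matters in this assay: dimethylamino in place of sulfo gives an at least 4.3-fold lower number from compound 3 to compound 4 (0.63 log units; beyond the scatter). The earlier step concerned only a group on an aromatic carbon, so it said nothing about this chain. The full size of the step stays unknown because compound 3 stands at a limit, not a number: the limit of > 10 mg/kg in this assay, at which 1 of the 4 values shown sits.

A carboxylic acid or a primary amine at the chain end would help show whether losing sulfo or gaining dimethylamino drives the difference. A longer chain could show how much the chain length matters.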